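Restoring a Substituted Sulfonamide in a Urea Series

A few compounds are considered here, and "the series" means these few. Any claim that something is new, unique, unknown or untested is made for them only; others in the source may bear on it.

Compound 2 `NS(=O)(=O)c1ccc(NC(=O)NCc2ccncc2)cc1` carries a plain amino group on its sulfonyl sulfur. In an assay on isolated protein for activation of Nicotinamide phosphoribosyltransferase (Homo sapiens) (a higher number here means that more compound is needed for the effect, a lower number that less compound is needed), compound 2 gives 14300 nM. Among the numbers shown this is the highest of two; the other number belongs to compound 1 `CN(Cc1ccccc1)S(=O)(=O)c1ccc(NC(=O)NCc2ccncc2)cc1`, which in this assay gives 23 nM. The step of a 620-fold higher number from compound 1 to compound 2 (2.79 log units; beyond the scatter) is large and lies beyond the scatter, and it consists of nothing but the exchange of benzyl(methyl)amino for amino on the sulfonyl sulfur. Compound 3 `CCOC(=O)c1ccc(NC(=O)NCc2ccnnc2)cc1` differs in two places at once and gives only a limit of the assay: in this assay compound 3 gives > 100000 nM.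

Compound 4 `CN(C1CCCC1)S(=O)(=O)c1ccc(NC(=O)NCc2ccncc2)cc1` has not been measured. It differs from compound 2 by cyclopentyl(methyl)amino in place of amino on a sulfonyl sulfur. This change runs back towards the substituted sulfonamide of compound 1. Going by the values given here, the only measured step that bears on it is a 620-fold higher number from compound 1 to compound 2 (2.79 log units; beyond the scatter), taken in the opposite direction. A large drop in this assay is therefore expected. The group entering is cyclopentyl(methyl)amino rather than the benzyl(methyl)amino of compound 1, and the estimate is kept a little above the number of compound 1. Compound 4 is expected to give 60 nM, between 15 nM and 300 nM. That estimate means an expected step of a 240-fold lower number from compound 2 to compound 4 (2.38 log units; beyond the scatter).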

Compound 4, half-maximal effective concentration: 123 nM
Estimate against measurement, compound 4: 2.1-fold (0.31 log units) below; low and high end bracket the measured number.
By their numbers in this assay, from the lowest: compound 1; then compound 4; then compound 2. At a limit, above all of these: compound 3.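

The earlier compounds shown here showed only that losing the benzyl(methyl)amino group from the sulfonyl sulfur is costly in this assay. Compound 4 shows that this loss can be largely recovered without a benzyl group: the change to cyclopentyl(methyl)amino gives a 120-fold lower number from compound 2 to compound 4 (2.07 log units; beyond the scatter) on a large scale, with one five-membered non-aromatic ring of carbon only taking the place of the benzyl group. The choice of group on the sulfonamide nitrogen still counts, though, as swapping cyclopentyl for benzyl gives a 5.3-fold higher number from compound 1 to compound 4 (0.73 log units; beyond the scatter) and is a modest step, much smaller than the gap that separates either substituted compound from the plain amino group of compound 2.

On these data alone, with only these two substituted groups, it remains open how an open-chain group such as diethylamino, or a ring holding a second heteroatom such as morpholine, would behave on the sulfonyl sulfur, and whether the methyl group on the sulfonamide nitrogen is needed at all. Nothing among the data given explains why the substituted sulfonamides give so much lower numbers than the plain one.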